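This account rests on a few compounds, and the source may have more. Where it says the series, first, only, none or still open, it means among the compounds named here.

Three compounds were measured in a functional assay on LoVo cells (Homo sapiens) for inhibition, read by MTT assay, with a stated time of 24 h; on this read-out higher numbers stand for weaker inhibition and lower numbers for stronger inhibition:

Compound 1 `CC1(C)[C@H]2CC[C@]1(C)N(Cc1cn(-c3cccc(Cl)c3)nn1)C(=O)C2`: 70 nM
Compound 2 `CC1(C)[C@H]2CC[C@]1(C)N(Cc1cn(-c3ccc(Cl)cc3)nn1)C(=O)C2`: 160 nM
Compound 3 `Cc1ccc(-n2cc(CN3C(=O)C[C@@H]4CC[C@@]3(C)C4(C)C)nn2)cc1`: 50 nM

Compound 1 holds the second highest of the three numbers. Its nearest neighbour is compound 3, reached by a 1.4-fold lower number from compound 1 to compound 3 (0.15 log units; within the scatter), a change that stays within the scatter; its furthest is compound 2, reached by a 2.3-fold higher number from compound 1 to compound 2 (0.36 log units; beyond the scatter).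

Compound 4 `CC1(C)[C@H]2CC[C@]1(C)N(Cc1cn(-c3ccc(F)cc3)nn1)C(=O)C2` has not been measured. It differs from compound 1 as follows: 4-fluorophenyl in place of 3-chlorophenyl on an aromatic nitrogen. Among the measured compounds shown here, two measured steps bear on this. Putting 4-chlorophenyl in place of 3-chlorophenyl gave a 2.3-fold higher number from compound 1 to compound 2 (0.36 log units; beyond the scatter), a modest weakening. Putting methyl in place of chloro on that 4-substituted ring gave a 3.2-fold lower number from compound 2 to compound 3 (0.51 log units; beyond the scatter), a modest strengthening, so the group at that aromatic carbon matters by a modest amount in either direction. For the measured compounds named here, no measured step covers 4-fluorophenyl itself, so the direction for compound 4 is uncertain, and the expected step of a 1.4-fold higher number from compound 1 to compound 4 (0.15 log units; within the scatter) is a small one, likely within the scatter. Compound 4 is therefore estimated at 100 nM, in a range from 40 nM to 250 nM.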

Compound 4, half-maximal inhibitory concentration: 40 nM
The estimate for compound 4 lay 2.5-fold (0.40 log units) above the measured number, within the range that was stated.
By their numbers in this assay, from the lowest: compounds 4, 3 and 1 (each within the scatter of the next); then compound 2.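

Compound 4 shows that a group on the ring of 4-fluorophenyl does not in itself carry the loss seen with 4-chlorophenyl: exchanging 3-chlorophenyl for 4-fluorophenyl stays within the scatter in this assay (a 1.8-fold lower number from compound 1 to compound 4 (0.24 log units; within the scatter)). Fluoro in place of methyl also cannot be told apart (a 1.3-fold lower number from compound 3 to compound 4 (0.10 log units; within the scatter)), whereas fluoro in place of chloro is a modest strengthening (a 4.0-fold lower number from compound 2 to compound 4 (0.60 log units; beyond the scatter)). Among these compounds, the weaker reading therefore belongs to compound 2 alone, and it is chloro on that ring, not fluoro or methyl, that sets it apart.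

Nothing shown here explains why chloro differs from fluoro and methyl. Also open, as far as these compounds go, are how fluoro or methyl would read in the place chloro holds in 3-chlorophenyl, and how an amine or a carboxylic acid would read in place of fluoro in 4-fluorophenyl.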